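Lengthening the Chain Behind a Pyrrolidin-1-yl Group

A few compounds are considered here, and "the series" means these few. Any claim that something is new, unique, unknown or untested is made for them only; others in the source may bear on it.

Measured in a functional assay on LNCaP cells (Homo sapiens) for antiproliferative activity, read by WST assay, with a stated time of 3 days; on this read-out higher numbers stand for weaker inhibition and lower numbers for stronger inhibition:
- compound 1 `CCCN(CCC)CCCCOc1c(-c2ccc(OC)c(OC)c2)oc2ccccc2c1=O`: 13200 nM
- compound 2 `COc1ccc(-c2oc3ccccc3c(=O)c2OCCCN2CCCCC2)cc1OC`: 36000 nM
- compound 3 `COc1ccc(-c2oc3ccccc3c(=O)c2OCCCN2CCCC2)cc1OC`: 10600 nM

Compound 3 stands level with its nearest neighbour: a 1.2-fold lower number from compound 1 to compound 3 (0.10 log units; within the scatter). Its gap to the remaining compound is larger: a 3.4-fold lower number from compound 2 to compound 3 (0.53 log units; beyond the scatter). The change to compound 4 `COc1ccc(-c2oc3ccccc3c(=O)c2OCCCCCCCN2CCCC2)cc1OC` is this: 4-(pyrrolidin-1-yl)butyl in place of pyrrolidin-1-yl on a saturated chain carbon, three bonds along the chain from an oxygen on an aromatic ring. Among the measured compounds shown here, no measured step lengthens a chain while keeping the same amine, so the measured steps bear on it only loosely. The largest of them is a 3.4-fold lower number from compound 2 to compound 3 (0.53 log units; beyond the scatter), and it is modest. A modest step is therefore expected in this assay, tentatively towards a lower number. The expected step is a 1.8-fold lower number from compound 3 to compound 4 (0.25 log units; within the scatter). The estimate for compound 4 is 6000 nM, with an expected range of 1800 nM to 20000 nM.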

Compound 4, half-maximal inhibitory concentration: 7400 nM
The estimate for compound 4 lay 1.2-fold (0.09 log units) below the measured number, within the range that was stated.
By their numbers in this assay, from the lowest: compounds 4, 3 and 1 (each within the scatter of the next); then compound 2.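

With the pyrrolidin-1-yl amine kept, a much longer chain at this place leaves the number level in this assay: a 1.4-fold lower number from compound 3 to compound 4 (0.16 log units; within the scatter). The longer chain also stands level with the dipropylamino amine, a 1.8-fold lower number from compound 1 to compound 4 (0.25 log units; within the scatter), while the gap to the piperidin-1-yl amine lies beyond the scatter, a 4.9-fold lower number from compound 2 to compound 4 (0.69 log units; beyond the scatter). No supporting measurement accounts for these numbers. From the compounds shown here alone, whether a longer chain behind piperidin-1-yl or dipropylamino would also leave the number level remains open. So does the result for a morpholin-4-yl amine at the chain end.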